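From 2-methylprop-2-en-1-yl to cyclobutyl

The compounds below may be only part of what the source reports. "The series", "measured", "known", "first", "only" and "open" are said of these compounds alone.

In a physicochemical assay for acid dissociation, compound 1 (`C=C(C)CN(C1=NCCN1)c1c(Br)cccc1Br`) gives 10.7 while compound 2 (`C/C=C/CN(C1=NCCN1)c1c(Br)cccc1Br`) gives 11 and compound 3 (`C=C(C)CCN(C1=NCCN1)c1c(Br)cccc1Br`) gives 10.9 as its reading, so compound 3 stands within the scatter of both others. Compound 4 (`Brc1cccc(Br)c1N(CC1CCC1)C1=NCCN1`) differs from compound 3 (cyclobutyl in place of 2-methylprop-2-en-1-yl on a saturated chain carbon bound to a nitrogen on an aromatic ring) by cyclobutyl in place of 2-methylprop-2-en-1-yl on a saturated chain carbon bound to a nitrogen on an aromatic ring. The measured steps that bear on this change are a number 0.20 log units higher from compound 1 to compound 3 (within the scatter) and a number 0.10 log units lower from compound 2 to compound 3 (within the scatter) and a number 0.30 log units higher from compound 1 to compound 2 (within the scatter) and all stay within the scatter, though none of them puts a ring in that chain. No step beyond the scatter is therefore expected in this assay (a number 0.10 log units higher from compound 3 to compound 4 (within the scatter)). Compound 4 is estimated at 11 (range 10.6 to 11.4).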

Compound 4, acid dissociation constant: 10.9
Beside the measured number, compound 4's estimate is 0.10 log units above it, and the stated range covers the measured number.
By their numbers in this assay, from the lowest: compounds 1, 3, 4 and 2 (each within the scatter of the next).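

In this assay, putting a ring on the saturated chain carbon bound to a nitrogen on an aromatic ring leaves the reading in place (no change at the digits printed from compound 3 to compound 4 (within the scatter)). The same holds against the other two compounds (a number 0.10 log units lower from compound 2 to compound 4 (within the scatter); a number 0.20 log units higher from compound 1 to compound 4 (within the scatter)), so at this place cyclobutyl reads alike with the open-chain groups that carry a double bond. No supporting measurement explains this reading.

As far as these compounds go, whether an amine, a carboxylic acid or a longer chain at this place would move the number beyond the scatter stays open. So does whether cyclobutyl behaves the same way on another core.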